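Swapping methoxy for methyl on the amide aryl ring

A few compounds are considered here, and "the series" means these few. Any claim that something is new, unique, unknown or untested is made for them only; others in the source may bear on it.

Compound 1 `O=C(Nc1cccc(-c2oc3cc(-c4ccc(F)cc4)ccc3c(=O)c2O)c1)c1ccccc1F`: 7570 nM
Compound 2 `O=C(Nc1cccc(-c2oc3cc(-c4ccc(F)cc4)ccc3c(=O)c2O)c1)c1ccc(F)cc1`: 8590 nM
Compound 3 `COc1ccc(C(=O)Nc2cccc(-c3oc4cc(-c5ccc(F)cc5)ccc4c(=O)c3O)c2)cc1`: 6250 nM

Of the compounds shown here, three sharing one core have been tested in a functional assay on MCF7 cells (Homo sapiens) for antiproliferative activity, read by CCK-8 assay, with a stated time of 72 h; on this read-out higher numbers stand for weaker inhibition and lower numbers for stronger inhibition. They differ only in the aryl group attached to the amide carbonyl. Compound 3 gives the lowest of the three numbers, but the gaps to it, a 1.2-fold lower number from compound 1 to compound 3 (0.08 log units; within the scatter) and a 1.4-fold lower number from compound 2 to compound 3 (0.14 log units; within the scatter), both lie within the usual scatter, so the three compounds cannot be told apart on these data.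

The next compound, compound 4 `Cc1ccc(C(=O)Nc2cccc(-c3oc4cc(-c5ccc(F)cc5)ccc4c(=O)c3O)c2)cc1`, is made from compound 3 by a single change: methyl in place of methoxy on an aromatic carbon. The step that bears most directly on it is a 1.4-fold lower number from compound 2 to compound 3 (0.14 log units; within the scatter), where another swap at the same aromatic carbon, fluoro to methoxy, left the number within the scatter. The step of a 1.1-fold higher number from compound 1 to compound 2 (0.05 log units; within the scatter), which moves the fluoro to a different position on that ring, was also within the scatter. Every change to this aryl group so far has therefore been silent, and the methyl for methoxy swap is expected to behave the same way, with no step beyond the scatter in this assay.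

Compound 4 is thus estimated at 7000 nM, with a range from 3500 nM to 14000 nM. This corresponds to an expected step of a 1.1-fold higher number from compound 3 to compound 4 (0.05 log units; within the scatter).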

Compound 4, half-maximal inhibitory concentration: 2400 nM
Compound 4: the middle estimate sits 2.9-fold (0.46 log units) above what was measured, outside the stated range (below it).
By their numbers in this assay, from the lowest: compound 4; then compounds 3, 1 and 2 (each within the scatter of the next).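

In this assay, going by these compounds alone, the aryl group on the amide carbonyl turns out not to be silent after all: methyl in place of methoxy, on the ring carbon para to a large group, gives a 2.6-fold lower number from compound 3 to compound 4 (0.42 log units; beyond the scatter), the first step to lie beyond the scatter, though still a modest one. Compound 4 also separates from the two fluorinated compounds, with a 3.6-fold lower number from compound 2 to compound 4 (0.55 log units; beyond the scatter) and a 3.2-fold lower number from compound 1 to compound 4 (0.50 log units; beyond the scatter), so this small methyl group stands out from all three other aryl groups, whereas those three could not be told apart. Nothing measured on these compounds accounts for the difference between methyl and the other groups.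

From the compounds shown here alone, it remains open whether the gain is particular to methyl or would carry over to an ethyl, an isopropyl or a chloro group on the same carbon. Going by these compounds, it is equally open whether 2-methylphenyl would match 4-methylphenyl, or whether the benefit depends on where the methyl sits on the ring.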